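Swapping butyl for phenyl on the amine nitrogen

This account rests on a few compounds, and the source may have more. Where it says the series, first, only, none or still open, it means among the compounds named here.

Compound 1 `CCCCNc1nc(NCc2ccccc2)c2ccccc2n1` and compound 3 `CCCCNc1nc(NCc2ccccc2)nc2ccccc12` are built from the same atoms joined differently; the difference between the two cores is not broken down here. In a physicochemical assay for solubility, at pH 2 (a lower number here means a less soluble compound, a higher number a more soluble compound), compound 1 gives >= 30000 nM, which is a limit of the assay rather than a number. In this assay compound 3 gives >= 30000 nM, likewise a limit. Compound 2 `c1ccc(CNc2nc(Nc3ccccc3)nc3ccccc23)cc1` differs from compound 1 by phenyl in place of butyl on a nitrogen on an aromatic ring. In this assay compound 2 gives <= 5000 nM, again a limit. That change made an at least 6.0-fold lower number from compound 1 to compound 2 (0.77 log units; beyond the scatter). Both ends of this step sit at limits, the limit of >= 30000 nM in this assay, at which 2 of the 3 values shown sit, and (the limit of <= 5000 nM in this assay, at which 1 of the 3 values shown sits), so its true size is not known. Compound 4 `c1ccc(CNc2nc(Nc3ccccc3)c3ccccc3n2)cc1` is the unmeasured partner of compound 3 and carries the same change, (phenyl in place of butyl on a nitrogen on an aromatic ring), the second time it occurs among these compounds. A drop of similar size is expected, resting on the measured step of an at least 6.0-fold lower number from compound 1 to compound 2 (0.77 log units; beyond the scatter). The expected step is an at least 7.5-fold lower number from compound 3 to compound 4 (0.87 log units; beyond the scatter). Compound 4 is expected to give about 4000 nM, within a range from 1000 nM to 15000 nM.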

Compound 4, solubility: >= 30000 nM
Compound 4: only a limit was reported; the forecaster's own chance of this, stated with the estimate: 60%; middle value at least 7.5-fold (0.87 log units) from the limit.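

In this assay, compound 3 and compound 4 both sit at a limit of the assay rather than at a number, so the step between them cannot be read. The compounds shown leave open how large the change from butyl to phenyl really is on the core of compound 3, and whether it resembles the other measured case, an at least 6.0-fold lower number from compound 1 to compound 2 (0.77 log units; beyond the scatter).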